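The source may report more compounds than this note shows. Statements on the series, on what has been measured and on what is new or still open speak of the compounds shown alone.

Working notes on the series. Compound 1 `NC(=O)c1cc(Cl)c2c(Cl)c(C#CCCO)n([C@H]3CCCNC3)c2n1` gives 56 nM in a functional assay on KG-1 cells (Homo sapiens) for antiproliferative activity; a lower number here means that less compound is needed, a higher number that more compound is needed for the effect. Compound 2 `CC(C)(CC#Cc1c(Cl)c2c(Cl)cc(C(N)=O)nc2n1[C@H]1CCCNC1)C(N)=O` gives 269 nM in this assay, the highest of the two single numbers in hand; the step of a 4.8-fold higher number from compound 1 to compound 2 (0.68 log units; beyond the scatter) is beyond the scatter. Compound 3 `NC(=O)c1cc(Cl)c2c(Cl)c(C#CC3CNCCO3)n([C@H]3CCCNC3)c2n1` has two entries, 365 nM; 197 nM (2 entries), in this assay, and the spread between them the several entries of compound 3 in this assay, 365 nM; 197 nM (2 entries) shows how far repeat measurements can sit apart.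

Compound 4 `COC(C)(C)CC#Cc1c(Cl)c2c(Cl)cc(C(N)=O)nc2n1[C@H]1CCCNC1` is not yet measured. It differs from compound 2 by methoxy in place of carbamoyl on a saturated chain carbon bound to three saturated chain carbons. Within the data shown here, no measured step in this set exchanges a carbamoyl for a methoxy, so the only comparison that bears on it is a 4.8-fold higher number from compound 1 to compound 2 (0.68 log units; beyond the scatter), where a polar hydroxymethyl terminus on the chain was replaced by the 1-carbamoyl-1-methylethyl group and the number rose. The methoxy analogue keeps the branched chain of compound 2 and removes only the carbamoyl, so the expected step is small: a 1.3-fold lower number from compound 2 to compound 4 (0.11 log units; within the scatter), within the scatter. Compound 4 is therefore expected to give about 210 nM in this assay, between 70 nM and 650 nM.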

Compound 4, half-maximal effective concentration: 172 nM
Compound 4: middle estimate off by 1.2-fold (0.09 log units), on the high side; low and high end bracket the measured number.
By their numbers in this assay, from the lowest: compound 1; then compounds 4 and 2 (each within the scatter of the next).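

Methoxy in place of carbamoyl on a saturated chain carbon bound to three saturated chain carbons gives a 1.6-fold lower number from compound 2 to compound 4 (0.19 log units; within the scatter), so in this assay the numbers do not separate these two groups at this place, even though the hydrogen-bond donor of the carbamoyl is gone. The step from the hydroxymethyl chain also stays beyond the scatter with the 1-methoxy-1-methylethyl group, at a 3.1-fold higher number from compound 1 to compound 4 (0.49 log units; beyond the scatter), so a gap from compound 1 does not require the carbamoyl. The small difference between compound 2 and compound 4 should be read against the repeats of a single compound: the several entries of compound 3 in this assay, 365 nM; 197 nM (2 entries)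

Still open, as far as these compounds go, is whether the gap from compound 1 follows the branching of the chain or the terminal hydroxyl. A hydroxyl or an amine on the same branched carbon would bear on this, as would a carboxylic acid there.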